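The compounds below may be only part of what the source reports. "The series", "measured", "known", "first", "only" and "open" are said of these compounds alone.

Measured so far:
compound 1 `CCn1c(C(C)NS(=O)(=O)c2ccc(Cl)cc2)nc2ncccc21`: compound 1 gives 15 mL.min-1.g-1
compound 2 `CCn1c([C@@H](C)NS(=O)(=O)c2ccccc2)nc2ccc(C(F)(F)F)cc21`: compound 2 gives 14 mL.min-1.g-1

Both values come from an ADME assay (liver) for metabolic stability, with Liver microsome (Homo sapiens) as the target, read by LC-MS, using microsomes and NADPH, with a stated time of 5 min, at 37 degrees C; on this read-out higher numbers stand for fast clearance and lower numbers for slow clearance. In this assay compound 2 gives 14 mL.min-1.g-1, and compound 1 gives 15 mL.min-1.g-1; the two numbers lie within the usual scatter of each other, so nothing separates compound 2 from compound 1 on this read-out.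

Compound 3 `CCn1c([C@@H](C)NS(=O)(=O)c2cnn(C(C)C)c2C)nc2ccc(C(F)(F)F)cc21` is not yet measured in this assay. It differs from compound 2 in one place: 1-isopropyl-5-methyl-1H-pyrazol-4-yl in place of phenyl on a sulfonyl sulfur. Among the measured compounds shown here, no pair of measured compounds shows this change, so there is no step to lean on, and the two measured values give no trend to extend.

The expectation for compound 3 is a step that stays within the scatter, a 1.2-fold lower number from compound 2 to compound 3 (0.07 log units; within the scatter), with no confident direction. The value expected for compound 3 in this assay is 12 mL.min-1.g-1, in a range from 5 mL.min-1.g-1 to 30 mL.min-1.g-1.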

Compound 3, intrinsic clearance in microsomes: > 100 mL.min-1.g-1
Compound 3 ended at the assay's limit; the forecaster's own chance of this, stated with the estimate: 5%; at least 8.3-fold (0.92 log units) between middle value and limit.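

In this assay, the group on the sulfonyl sulfur proves able to move clearance strongly: 1-isopropyl-5-methyl-1H-pyrazol-4-yl in place of phenyl gives an at least 7.1-fold higher number from compound 2 to compound 3 (0.85 log units; beyond the scatter). With the rest of compound 2 kept, this single change is enough to carry the series from a measurable value to the edge of the read-out. The value of compound 3 is a limit and not a number, so this step marks only a minimum size: the limit of > 100 mL.min-1.g-1 in this assay, at which 1 of the 3 values shown sits.

The compounds shown do not separate the contribution of the five-membered aromatic ring from that of its isopropyl and methyl substituents, and they leave the true clearance of compound 3 unknown. Going by these compounds, whether an unsubstituted pyrazol-4-yl or a pyridyl on the sulfonyl sulfur behaves like compound 2 or like compound 3 remains open.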